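This account rests on a few compounds, and the source may have more. Where it says the series, first, only, none or still open, it means among the compounds named here.

Compound 1, `Nc1sc(-c2ccc(Cl)cc2)c(-c2ccc(Cl)cc2)c1C(=O)NCc1ccccc1`: 31800 nM in a functional assay on PC-3 cells (Homo sapiens) for inhibition, read by sulforhodamine B assay, with a stated time of 72 h; a lower number here means a stronger inhibitor, a higher number a weaker inhibitor
Compound 2, `Nc1sc(-c2ccc(Cl)cc2)c(-c2ccc(Cl)cc2)c1C(=O)N1CCC(=O)CC1=O`: 9230 nM in this assay
Compound 3, `CC1CCN(C(=O)c2c(N)sc(-c3ccc(Cl)cc3)c2-c2ccc(Cl)cc2)CC1`: 5750 nM in this assay

Among these three numbers compound 1 gives the highest: a 3.4-fold lower number from compound 1 to compound 2 (0.54 log units; beyond the scatter) and a 5.5-fold lower number from compound 1 to compound 3 (0.74 log units; beyond the scatter), both beyond the scatter. Compound 4, `CCCCNC(=O)c1c(N)sc(-c2ccc(Cl)cc2)c1-c1ccc(Cl)cc1`, keeps the shared core of compound 1 and alters only the amide substituent: propyl in place of phenyl on a saturated chain carbon bound to an amide-type nitrogen. Among the measured compounds shown here, the two measured steps from compound 1 each swap benzylamino for a ring-bearing amide nitrogen substituent and both lowered the number modestly; no measured pair trades a phenyl for a propyl, so those steps bear on compound 4 only loosely. Every change on this side so far has lowered the number, so a small lowering, or none beyond the scatter, is expected in this assay. Compound 4 is therefore estimated at 20000 nM (range 8000 nM to 50000 nM), which would mean an expected step of a 1.6-fold lower number from compound 1 to compound 4 (0.20 log units; within the scatter).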

Compound 4, half-maximal inhibitory concentration: 17800 nM
For compound 4 the middle estimate is 1.1-fold (0.05 log units) above the measured one, and the stated range covers the measured number.
By their numbers in this assay, from the lowest: compounds 3, 2, 4 and 1 (each within the scatter of the next, the first and the last beyond it).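

In this assay, propyl in place of phenyl on a saturated chain carbon bound to an amide-type nitrogen gives a 1.8-fold lower number from compound 1 to compound 4 (0.25 log units; within the scatter) and so leaves benzylamino and butylamino unseparated. Butylamino also stays unseparated from 2,4-dioxopiperidin-1-yl on a carbonyl carbon, with a 1.9-fold higher number from compound 2 to compound 4 (0.29 log units; within the scatter), but it does separate from 4-methylpiperidin-1-yl, with a 3.1-fold higher number from compound 3 to compound 4 (0.49 log units; beyond the scatter) as the only step here to do so. Nothing available gives a reason for these results.

The compounds shown leave open how a chain ending in an amine or a carboxylic acid would read at this place. They also do not tell whether a longer chain or a morpholine ring on the carbonyl carbon would differ from butylamino or 4-methylpiperidin-1-yl.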